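Shifting a single methoxy group on the benzylamine arm

This account rests on a few compounds, and the source may have more. Where it says the series, first, only, none or still open, it means among the compounds named here.

The series shares one core, a bis(trifluoromethyl)benzenesulfonamide joined through a three-carbon chain to a benzylamine. Compound 1 `COc1ccc(CNCCCNS(=O)(=O)c2cc(C(F)(F)F)cc(C(F)(F)F)c2)cc1OC` gives 1900 nM in a functional assay on MCF7 cells (Homo sapiens) for inhibition, read by MTT assay, with a stated time of 72 h; a lower number here means a stronger inhibitor of growth, a higher number a weaker inhibitor of growth. Compound 2 `COc1cccc(CNCCCNS(=O)(=O)c2cc(C(F)(F)F)cc(C(F)(F)F)c2)c1` gives 2400 nM, and compound 3 `O=S(=O)(NCCCNCc1ccc(Cl)c(C(F)(F)F)c1)c1cc(C(F)(F)F)cc(C(F)(F)F)c1` gives 3500 nM. Compound 2 sits between its two neighbours, yet both a 1.3-fold higher number from compound 1 to compound 2 (0.10 log units; within the scatter) and a 1.5-fold higher number from compound 2 to compound 3 (0.16 log units; within the scatter) stay within the scatter, and so does a 1.8-fold higher number from compound 1 to compound 3 (0.27 log units; within the scatter); the three measured compounds are not separated by this assay.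

Compound 4 `COc1ccc(CNCCCNS(=O)(=O)c2cc(C(F)(F)F)cc(C(F)(F)F)c2)cc1` has not been measured. Its difference from compound 2 is 4-methoxyphenyl in place of 3-methoxyphenyl on a saturated chain carbon bound to an amine nitrogen. Among the compounds with values here, the only measured step that touches this aryl group is a 1.3-fold higher number from compound 1 to compound 2 (0.10 log units; within the scatter), which removed a methoxy without a change beyond the scatter, and the larger swap a 1.5-fold higher number from compound 2 to compound 3 (0.16 log units; within the scatter) was also flat. Compound 4 is therefore expected to land close to compound 2, with an expected step of a 1.1-fold lower number from compound 2 to compound 4 (0.04 log units; within the scatter). For compound 4 the estimate is 2200 nM, within 1000 nM to 4800 nM.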

Compound 4, concentration for 50% growth inhibition: 2500 nM
Compound 4: middle estimate off by 1.1-fold (0.06 log units), on the low side; low and high end bracket the measured number.
By their numbers in this assay, from the lowest: compounds 1, 2, 4 and 3 (each within the scatter of the next).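

Moving the methoxy from 3-methoxyphenyl to 4-methoxyphenyl, on a saturated chain carbon bound to an amine nitrogen and with the same atoms in the group, gives a 1.0-fold higher number from compound 2 to compound 4 (0.02 log units; within the scatter) and so shows that this assay does not tell these two placements apart. The other new comparisons read the same way, with a 1.3-fold higher number from compound 1 to compound 4 (0.12 log units; within the scatter) for hydrogen in place of methoxy on an aromatic carbon and a 1.4-fold lower number from compound 3 to compound 4 (0.15 log units; within the scatter) for 4-methoxyphenyl in place of 4-chloro-3-(trifluoromethyl)phenyl, so all four compounds remain unseparated. Nothing at hand offers an explanation for this flat result.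

Still open, as far as these compounds go, is whether a carboxylic acid or a dimethylamino group on this aryl group would move the number beyond the scatter. Also open, from the compounds shown here alone, is what a longer chain in the shared core would do in this assay on these cells.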